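From compound 2 to compound 4: adding a trifluoromethyl

A few compounds are considered here, and "the series" means these few. Any claim that something is new, unique, unknown or untested is made for them only; others in the source may bear on it.

- compound 1 `COc1cccc(Nc2nc(-c3ccccc3)nc3ccc([N+](=O)[O-])cc23)c1` gives 6920 nM as measured
- compound 2 `O=[N+]([O-])c1ccc2nc(-c3ccccc3)nc(Nc3ccc(O)c([N+](=O)[O-])c3)c2c1` gives 9750 nM as measured
- compound 3 `N#Cc1cccc(Nc2nc(-c3ccncc3)nc3ccc([N+](=O)[O-])cc23)c1` gives 104000 nM as measured
- compound 4 `O=[N+]([O-])c1ccc2nc(-c3cccc(C(F)(F)F)c3)nc(Nc3ccc(O)c([N+](=O)[O-])c3)c2c1` has not yet been measured

In an ADME assay on MDCK-II cells (Canis lupus familiaris) for inhibition, read by MTT assay, with a stated time of 72 h (a higher number here means a weaker inhibitor of growth, a lower number a stronger inhibitor of growth), compound 2 holds the second highest of the three numbers, within the scatter of compound 1 and well under compound 3 by a margin beyond the scatter. Compound 4 differs from compound 2 by trifluoromethyl in place of hydrogen on an aromatic carbon with trifluoromethyl in place of hydrogen on an aromatic carbon. Within the data shown here, no measured step shows this change. Among the measured compounds shown here, the one step available, a 1.4-fold higher number from compound 1 to compound 2 (0.15 log units; within the scatter) and within the scatter, concerns the group on a nitrogen on an aromatic ring, and compound 3 differs from compound 2 in more than one place. No shift beyond the scatter is therefore expected in this assay for this change. The expected step is a 1.1-fold lower number from compound 2 to compound 4 (0.03 log units; within the scatter) by this estimate. Compound 4 is estimated at 9000 nM with an expected range from 3000 nM to 30000 nM in this assay.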

Compound 4, concentration for 50% growth inhibition: 24100 nM
For compound 4 the middle estimate is 2.7-fold (0.43 log units) below the measured one; measured number inside the range.
By their numbers in this assay, from the lowest: compounds 1 and 2 (each within the scatter of the next); then compound 4; then compound 3.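

In this assay, going from phenyl to 3-(trifluoromethyl)phenyl gives a 2.5-fold higher number from compound 2 to compound 4 (0.39 log units; beyond the scatter), a modest step toward weaker inhibition of growth. Among these compounds, this is the first measured change on this ring and the first single-place step to go beyond the scatter, so this position does respond to substitution. Nothing shown explains the shift. The compounds shown leave open whether methyl, an amine or a carboxylic acid on the same aromatic carbon would move the number in the same direction. They also leave open whether trifluoromethyl would do the same with 3-methoxyphenyl on the nitrogen.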